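The compounds below may be only part of what the source reports. "The series", "measured", "known", "first", "only" and "open" are said of these compounds alone.

Measured so far:
- compound 1, `O=S1(=O)C=C(OCc2ccccc2)C(Cc2ccccc2)(Cc2ccccc2)O1`, in an ADME assay on HEL cells (Homo sapiens) for cytotoxicity, with a stated time of 3 days; a higher number here means that more compound is tolerated, a lower number that less compound is tolerated: 200000 nM
- compound 2, `CCC1(Cc2ccccc2)OS(=O)(=O)C=C1OCC#N`, in this assay: > 400000 nM, a limit of the assay

Among the compounds with values here, compound 1 holds the only number in this assay; the other value is a limit. For compound 2 the assay reports the limit of > 400000 nM in this assay, at which 1 of the 2 values shown sits, rather than a number.

Compound 3, `CCCC1(Cc2ccccc2)OS(=O)(=O)C=C1OCc1ccccc1`, differs from compound 1 by ethyl in place of phenyl on a saturated chain carbon bound to a saturated ring carbon. Within the data shown here, no measured pair in this assay shows what such a change does, so the step is expected to stay within the scatter: no change at the digits printed from compound 1 to compound 3 (within the scatter), with no direction claimed.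

Compound 3 is therefore estimated at 200000 nM in this assay, expected between 100000 nM and 400000 nM.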

Compound 3, minimum cytotoxic concentration: >= 400000 nM
Compound 3: a limit, no number; the forecaster's own chance of this, stated with the estimate: 30%; middle value at least 2.0-fold (0.30 log units) from the limit.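

In this assay, within the data shown here, this position gives the first readable step, with ethyl in place of phenyl on a saturated chain carbon bound to a saturated ring carbon: an at least 2.0-fold higher number from compound 1 to compound 3 (0.30 log units; that floor lies within the scatter). Compound 3 gives only a limit of the assay, not a number: the limit of >= 400000 nM in this assay, at which 1 of the 3 values shown sits. The step therefore has a floor and no fixed size, and it shows no drop in the tolerated concentration on this change.

As far as these compounds go, how far compound 3 lies past its limit remains open. So does the outcome with an amine, a carboxylic acid or a longer chain at this place.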